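The source may hold more compounds than are shown below. What is called first, only, known or untested is meant among the compounds shown, and "the series" means these compounds.

Measured so far:
- compound 1, `CCCc1cnc(N2CCC(C3Cc4cc(C5=CCN(S(=O)(=O)CCC)CC5)ccc4O3)CC2)nc1`: 58%
- compound 2, `CCCc1cnc(N2CCC(C3Cc4cc(C5=CCN(S(=O)(=O)CCC)CC5)cc(F)c4O3)CC2)nc1`: 74%
- compound 3, `CCCc1cnc(N2CCC(C3Cc4cc(C5=CCN(S(=O)(=O)CCCO)CC5)cc(F)c4O3)CC2)nc1`: 60%

All three were tested in an ADME assay (liver, Mus musculus) for metabolic stability, using microsomes, with a stated time of 10 min; on this read-out lower numbers stand for a less stable compound and higher numbers for a more stable compound. Compound 1 gives 58%. Compound 2 differs from compound 1 in one place, (fluoro in place of hydrogen on an aromatic carbon), and this change brought a number 16 percentage points higher from compound 1 to compound 2 (beyond the scatter). Compound 3 differs from compound 2 by a hydroxy group in place of hydrogen on a saturated chain carbon, three bonds along the chain from a sulfonyl sulfur, and here the step was a number 14 percentage points lower from compound 2 to compound 3 (beyond the scatter). Compared with compound 1, compound 3 differs in more than one place, so the difference between these two cores is not broken down here; their values lie within the scatter of each other.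

Compound 4, `CCCc1cnc(N2CCC(C3Cc4c(F)c(C5=CCN(S(=O)(=O)CCCO)CC5)cc(F)c4O3)CC2)nc1`, has not been measured. It differs from compound 3 by fluoro in place of hydrogen on an aromatic carbon. This is the same kind of change as from compound 1 to compound 2, but not the same: in compound 2 the new fluoro sits meta to a large group, whereas in compound 4 it sits ortho to a large group and para to a fluoro group. Because the earlier change gave a number 16 percentage points higher from compound 1 to compound 2 (beyond the scatter), a step of similar direction is expected, though the surroundings differ, so a somewhat smaller step is estimated: a number 10 percentage points higher from compound 3 to compound 4 (within the scatter). Compound 4 is therefore expected to give about 70% in this assay, estimated between 58% and 82%.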

Compound 4, percent of the compound remaining: 82%
Beside the measured number, compound 4's estimate is 12 percentage points below it; low and high end bracket the measured number.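

In this assay, placing fluoro in place of hydrogen on an aromatic carbon gave a number 22 percentage points higher from compound 3 to compound 4 (beyond the scatter). Set beside the earlier case, the same kind of change went in the same direction on both cores, and the sizes of the two steps cannot be told apart: the same change on two cores in this assay, a number 16 percentage points higher (beyond the scatter) from compound 1 to compound 2 and a number 22 percentage points higher (beyond the scatter) from compound 3 to compound 4, 6 percentage points apart, within the scatter of two such steps This shows that the gain carried over between these two cores, even though the core of compound 3 already holds a fluoro group and a hydroxy group on its sulfonyl chain; it does not show that the change will give a gain on every core in the series, and with the new fluoro at a different place in each case, two steps cannot separate the effect of its place from that of the core.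

The compounds shown leave open whether another small group at this aromatic carbon, such as chloro, methyl or a nitrile, would give a step of similar size. They also leave open how the doubly fluorinated core would behave if the hydroxy on the sulfonyl chain gave way to an amine, a carboxylic acid or a longer chain.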